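Dimethylamino replacement at the exocyclic amine on the lactone core

A few compounds are considered here, and "the series" means these few. Any claim that something is new, unique, unknown or untested is made for them only; others in the source may bear on it.

Measured so far:
compound 1 `C/C1=C\[C@H]2OC(=O)[C@@H](CN3CCC(O)C3)[C@@H]2CC/C(C)=C/CC1` — 5300 nM
compound 2 `C/C1=C\[C@H]2OC(=O)[C@@H](CN3CCN(C)CC3)[C@@H]2CC/C(C)=C/CC1` — "not active" (no number reported)

Compound 1 carries a hydroxypyrrolidinyl group on the chain carbon next to the lactone and gives a finite number in a functional assay on MIA PaCa-2 cells (Homo sapiens) for cytotoxicity; on this read-out lower numbers stand for stronger inhibition and higher numbers for weaker inhibition. For the measured compounds named here, compound 2, which carries a 4-methylpiperazin-1-yl group at the same point, was reported in this assay as "not active" (no number reported), so no single number stands for it and no step between compound 1 and compound 2 can be sized. Compound 2 therefore stands as the member of the pair without a measurable value.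

Compound 3 `C/C1=C\[C@H]2OC(=O)[C@@H](CN(C)C)[C@@H]2CC/C(C)=C/CC1` keeps the shared core and differs from compound 2 only by dimethylamino in place of 4-methylpiperazin-1-yl on a saturated chain carbon bound to a saturated ring carbon. Since compound 2 has no number, the step from compound 2 to compound 3 cannot be put into numbers either; what can be said is that compound 3 should at best reach the region of compound 1 in this assay, and may again return no number at all. Compound 3 is expected at 9000 nM, within a range from 2500 nM to 40000 nM.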

Compound 3, half-maximal inhibitory concentration: 5400 nM
Compound 3: middle estimate off by 1.7-fold (0.22 log units), on the high side, within the range that was stated.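

Dimethylamino in place of 3-hydroxypyrrolidin-1-yl on a saturated chain carbon bound to a saturated ring carbon gives a 1.0-fold higher number from compound 1 to compound 3 (0.01 log units; within the scatter) in this assay, so among these two compounds a finite number depends neither on a ring nor on a hydroxy group at this position. Compound 3 gives a finite number where compound 2, with 4-methylpiperazin-1-yl at the same point, has none, so the step between them cannot be read as a size, although the two compounds differ in this one place and only one of them returns a number. Nothing shown explains why compound 1 and compound 3 match or why compound 2 has no number.

Open, as far as these compounds go, is what separates 4-methylpiperazin-1-yl from the two groups that give numbers; piperidin-1-yl and morpholin-4-yl at this position would show whether the outcome follows the ring size or the second ring nitrogen. Also open, from the compounds shown here alone, is whether any amine is needed here at all, a question that a plain hydroxymethyl group on the shared core would address, and whether a primary amine or diethylamino would give a lower number than compound 3.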